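This account rests on a few compounds, and the source may have more. Where it says the series, first, only, none or still open, it means among the compounds named here.

Series notes. Compound 3 `Nc1ccccc1NC(=O)c1ccc(CSC(=S)N2CCN(c3ccc(F)cc3)CC2)cc1` is the current reference; in a functional assay on MGC-803 cells (Homo sapiens) for antiproliferative activity, read by CCK-8 assay, with a stated time of 72 h, tested at 2 uM (a higher number here means a stronger effect of the compound at the concentration tested, a lower number a weaker effect), compound 3 gives 18.8%. Compound 1 `Nc1ccccc1NC(=O)c1ccc(CSC(=S)N2CCN(c3cccnc3)CC2)cc1` gives 27.6% and compound 2 `COc1ccc(N2CCN(C(=S)SCc3ccc(C(=O)Nc4ccccc4N)cc3)CC2)cc1` gives 25.3%, so compound 3 holds the lowest of the three numbers, yet the steps of a number 8.8 percentage points lower from compound 1 to compound 3 (within the scatter) and a number 6.5 percentage points lower from compound 2 to compound 3 (within the scatter) keep it within the scatter of both. Compound 4 `Nc1ccccc1NC(=O)c1ccc(CSC(=S)N2CCN(Cc3ccncc3)CC2)cc1` differs from compound 3 by (pyridin-4-yl)methyl in place of 4-fluorophenyl on an amine nitrogen in a ring. Going by the values given here, the steps measured at this position, a number 2.3 percentage points lower from compound 1 to compound 2 (within the scatter) and a number 8.8 percentage points lower from compound 1 to compound 3 (within the scatter), both stay within the scatter, and none of the measured steps puts (pyridin-4-yl)methyl in place of 4-fluorophenyl. The expected step is therefore none beyond the scatter, a number 3.2 percentage points higher from compound 3 to compound 4 (within the scatter). For compound 4 the estimate is 22%, with a range from 10% to 36%.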

Compound 4, a percentage reported as inhibition, at one concentration (the size of the read-out at that concentration, not a potency): 18.4%
For compound 4 the middle estimate is 3.6 percentage points above the measured one; measured number inside the range.
By their numbers in this assay, from the lowest: compounds 4, 3, 2 and 1 (each within the scatter of the next).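

In this assay, (pyridin-4-yl)methyl on the amine nitrogen in a ring stays within the scatter of all three earlier groups, with a number 0.4 percentage points lower from compound 3 to compound 4 (within the scatter) and a number 6.9 percentage points lower from compound 2 to compound 4 (within the scatter) and a number 9.2 percentage points lower from compound 1 to compound 4 (within the scatter) as the steps. This position therefore shows no step beyond the scatter for this group either, so 4-fluorophenyl, 4-methoxyphenyl, pyridin-3-yl and (pyridin-4-yl)methyl cannot be ranked. No supporting evidence bears on this result. Open, on these data alone, is whether a carboxylic acid, a primary amine or a longer chain at this nitrogen would give a step beyond the scatter.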